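This account rests on a few compounds, and the source may have more. Where it says the series, first, only, none or still open, it means among the compounds named here.

Three closely related compounds have been tested in a functional assay on KB cells (nasopharynx, Homo sapiens) for antiproliferative activity; on this read-out lower numbers stand for stronger inhibition and higher numbers for weaker inhibition. In this test, compound 1 `N#Cc1c[nH]c2c(NS(=O)(=O)c3ccc(C(N)=O)cc3)cccc12` gives 15 ug/mL, compound 2 `N#Cc1ccc(S(=O)(=O)Nc2cccc3c(Cl)c[nH]c23)cc1` gives 11 ug/mL and compound 3 `NC(=O)c1ccc(S(=O)(=O)Nc2cccc3c(Cl)c[nH]c23)cc1` gives 21 ug/mL. Compound 3 therefore stands within the usual scatter of both other compounds.

The next compound, compound 4 `NS(=O)(=O)Cc1ccc(S(=O)(=O)Nc2cccc3c(Cl)c[nH]c23)cc1`, differs from compound 3 in one group: sulfamoylmethyl in place of carbamoyl on an aromatic carbon, para to a large group (sulfamoylmethyl in place of carbamoyl on an aromatic carbon). Two measured steps offer guidance. The closer one also changes the group at this place, with carbamoyl in place of cyano, and amounts to a 1.9-fold higher number from compound 2 to compound 3 (0.28 log units; within the scatter). The other, chloro in place of cyano on an aromatic carbon, amounts to a 1.4-fold higher number from compound 1 to compound 3 (0.15 log units; within the scatter). Among the measured compounds shown here, neither step goes beyond the scatter, but no measured compound carries sulfamoylmethyl, so this guidance is limited. No step beyond the scatter is therefore expected, and the estimated change is a 1.2-fold lower number from compound 3 to compound 4 (0.07 log units; within the scatter). Compound 4 is expected to give about 18 ug/mL, within an estimated range of 8 ug/mL to 40 ug/mL.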

Compound 4, half-maximal inhibitory concentration: 13 ug/mL
Compound 4: middle estimate off by 1.4-fold (0.14 log units), on the high side; low and high end bracket the measured number.
By their numbers in this assay, from the lowest: compounds 2, 4, 1 and 3 (each within the scatter of the next).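

With sulfamoylmethyl, the group on this aromatic carbon, para to a large group, grows from the 3 heavy atoms of carbamoyl to 5 and gains a sulfur, yet the number in this assay stays within the scatter (a 1.6-fold lower number from compound 3 to compound 4 (0.21 log units; within the scatter)). Set against cyano at the same place, sulfamoylmethyl also stays within the scatter (a 1.2-fold higher number from compound 2 to compound 4 (0.07 log units; within the scatter)). With the chloro-bearing core held constant, cyano, carbamoyl and sulfamoylmethyl therefore all give numbers within the scatter of one another, a flat picture that holds for these three groups only.

As far as these compounds go, whether a carboxylic acid, an amine or a longer chain at this place would move the number beyond the scatter remains open, as does whether sulfamoylmethyl behaves alike on the cyano-bearing core of compound 1. Nothing available here accounts for the similarity of these numbers.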